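The source may report more compounds than this note shows. Statements on the series, on what has been measured and on what is new or still open speak of the compounds shown alone.

Measured in a functional assay on A2780 ADR cells (Homo sapiens) for cytotoxicity, read by MTT assay, with a stated time of 24 h; on this read-out higher numbers stand for weaker inhibition and lower numbers for stronger inhibition:
- compound 1 `CCCCC[C@H](C[C@@H](O)C[C@H]1CC=CC(=O)O1)OC`: 18100 nM
- compound 2 `CCCCC[C@@H](C[C@@H](O)C[C@@H]1CC=CC(=O)O1)OC`: 46300 nM

Within the data shown here, compound 2 holds the higher number of the pair, and the only measured step is a 2.6-fold higher number from compound 1 to compound 2 (0.41 log units; beyond the scatter). That step bears directly on what follows, as the fact that compounds 1 and 2 differ only in the configuration as drawn. It changes a stereocentre at a saturated chain carbon and one at a saturated ring carbon together, and the data do not show how the effect divides between them.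

Compound 3 `CCCCC[C@H](C[C@@H](O)C[C@@H]1CC=CC(=O)O1)OC` departs from compound 2 as follows: the two compounds have the same atoms and bonds and differ only in configuration as drawn: 1 of 3 stereo elements differ; a stereocentre at a saturated chain carbon is drawn S in compound 2 and R in compound 3. Here a stereocentre at a saturated chain carbon is drawn S in compound 2 and R in compound 3. This repeats only the chain part of a 2.6-fold higher number from compound 1 to compound 2 (0.41 log units; beyond the scatter), so a smaller step towards lower numbers is expected in this assay, possibly not beyond the scatter. The expected change is a 1.6-fold lower number from compound 2 to compound 3 (0.20 log units; within the scatter). For compound 3 the estimate is 29000 nM, with an expected range from 12000 nM to 65000 nM.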

Compound 3, half-maximal inhibitory concentration: 91500 nM
The estimate for compound 3 lay 3.2-fold (0.50 log units) below the measured number, and the stated range ends below it.
By their numbers in this assay, from the lowest: compound 1; then compounds 2 and 3 (each within the scatter of the next).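

In this assay, the new compound separates the two stereocentres that changed together in the earlier pair. The effect of the saturated ring carbon can now be read alone because only that centre changes between these two compounds: the fact that compounds 1 and 3 differ only in the configuration as drawn Going from R to S at this carbon gives a 5.1-fold higher number from compound 1 to compound 3 (0.70 log units; beyond the scatter), whereas the saturated chain carbon, changed alone from S to R, gives a 2.0-fold higher number from compound 2 to compound 3 (0.30 log units; within the scatter), so among these compounds only the ring carbon change has a step beyond the scatter.

From the compounds shown here alone, the chain carbon has been changed only with the ring carbon drawn S, so its effect with the ring carbon drawn R remains open. Going by these compounds, it is also open whether an amine or a longer chain on the shared core would keep this dependence on the ring carbon's configuration.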